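A few compounds are considered here, and "the series" means these few. Any claim that something is new, unique, unknown or untested is made for them only; others in the source may bear on it.

Of the compounds shown here, two have numbers so far. Compound 1 `Cc1cc(-c2c(O)nc3cc(Cl)c(C(=O)Nc4cnsn4)cc3c2OCCC2CC3CCN2CC3)cc(C)c1C` gives 5.8 nM in a functional assay on CHO cells for inhibition of Gonadotropin-releasing hormone receptor (Homo sapiens); on this read-out lower numbers stand for stronger inhibition and higher numbers for weaker inhibition. Compound 2 `Cc1cc(-c2c(O)nc3cc(Cl)c(C(=O)Nc4ccncn4)cc3c2OCC[C@@H]2CCCCN2)cc(C)c1C` gives 2.2 nM in this assay, the lowest of the two numbers; compound 1 sits a gap away from it that is beyond the usual scatter. The two differ in more than one place, so no single step can be read between them.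

Compound 3 `Cc1cc(-c2c(O)nc3cc(Cl)c(C(=O)Nc4ccncn4)cc3c2OCCC2CCCO2)cc(C)c1C` is not yet measured. It is reached from compound 2 by one change: oxolan-2-yl in place of piperidin-2-yl on a saturated chain carbon, two bonds along the chain from an oxygen on an aromatic ring. Among the compounds with values here, the hydrogen-bond donor counted in the leaving group has no counterpart in the entering group.

Within the data shown here, no measured pair shows this kind of exchange, so the expectation rests on the change alone. A step in the direction of weaker inhibition, beyond the scatter, is expected: a 6.8-fold higher number from compound 2 to compound 3 (0.83 log units; beyond the scatter). Compound 3 is estimated at 15 nM, within 4 nM to 60 nM.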

Compound 3, half-maximal inhibitory concentration: 3.3 nM
For compound 3 the middle estimate is 4.5-fold (0.66 log units) above the measured one, outside the stated range (below it).
By their numbers in this assay, from the lowest: compounds 2, 3 and 1 (each within the scatter of the next, the first and the last beyond it).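

In this assay, the step of a 1.5-fold higher number from compound 2 to compound 3 (0.18 log units; within the scatter) shows that this place on the chain, a saturated chain carbon two bonds along from an oxygen on an aromatic ring, accepts oxolan-2-yl in place of piperidin-2-yl. The hydrogen-bond donor counted in piperidin-2-yl therefore is not required here for a value in this range, and a five-membered ring with an oxygen serves as well as a six-membered ring with a nitrogen. Nothing measured on these compounds gives a cause for this result.

The compounds shown leave open whether any hetero atom in this ring is needed at all, which a cyclopentyl group at the same place would address. Also open, as far as these compounds go, is how an open-chain group, such as a dimethylamino or methoxy end on the chain, would read.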